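A Urea Gives Way to a Fluorinated Amide

This account rests on a few compounds, and the source may have more. Where it says the series, first, only, none or still open, it means among the compounds named here.

Compound 1 `COc1cc(N(C)C(=O)c2ccc([N+](=O)[O-])cc2)cc(OC)c1OC` — in a functional assay on Daoy cells (Homo sapiens) for cytotoxicity, read by MTT assay, with a stated time of 72 h (on this read-out higher numbers stand for weaker inhibition and lower numbers for stronger inhibition), compound 1 gives >= 125000 nM, which is a limit of the assay rather than a number.
Compound 2 `COc1cc(N(C)C(=O)N(C)c2ccccc2)cc(OC)c1OC` — in this assay compound 2 gives "not determined" (no result reported).

Compound 2 stands nowhere on the numbers shown: it carries no result in this assay. Going by the values given here, the only measured value belongs to compound 1, and that value sits at the limit of >= 125000 nM in this assay, at which 1 of the 2 values shown sits. Compound 3 `COc1cc(N(C)C(=O)c2ccc(F)cc2)cc(OC)c1OC` arises from compound 2 through (4-fluorophenyl in place of methyl(phenyl)amino on a carbonyl carbon). No measured step links any two of these compounds, so neither the size nor the direction of the change from compound 2 to compound 3 can be read from the data; the one measured member, compound 1, offers only a limit and no numeric anchor. Compound 3 is therefore expected, with wide uncertainty, to fall near 80000 nM, in a range from 20000 nM to 200000 nM, and it may well return only a limit again.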

Compound 3, half-maximal inhibitory concentration: >= 125000 nM
Compound 3 was reported as a limit; the forecaster's own chance of this, stated with the estimate: 50%; middle value at least 1.5-fold (0.19 log units) away from the limit.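

No step can be read from compound 1 to compound 3, since each result is a limit of the assay rather than a number: the limit of >= 125000 nM in this assay, at which 2 of the 3 values shown sit.

The compounds shown leave open whether fluoro in place of nitro on an aromatic carbon changes the result at all, and where compound 2 stands.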